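The source may hold more compounds than are shown below. What is called first, only, known or untested is meant among the compounds shown, and "the series" means these compounds.

Measured compounds:
compound 1 `O=C(Nc1cccc(Cl)c1)c1cccc(Br)c1` — > 100000 nM
compound 2 `O=C(Nc1ccc(Sc2nc3ccccc3s2)c(Cl)c1)c1cccc(Br)c1` — > 100000 nM
compound 3 `O=C(Nc1ccc(Sc2nc3ccccc3s2)cc1)c1cccc(Br)c1` — > 100000 nM

Each of these three values is a limit of an assay for inhibition of HSP60/HSP10 (Homo sapiens), with a stated time of 60 min (a higher number here means a weaker inhibitor, a lower number a stronger inhibitor), not a number. In this assay compound 1 reaches only its limit of > 100000 nM. Compound 2 likewise sits at the limit, > 100000 nM. Compound 3 also gives only the limit > 100000 nM. Among the compounds with values here, the single step between measured compounds, a step that the two limits leave unreadable from compound 2 to compound 3, cannot be read because both ends sit at the limit (the limit of > 100000 nM in this assay, at which 3 of the 3 values shown sit).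

Compound 4 `COc1ccc(Br)cc1C(=O)Nc1ccc(Sc2nc3ccccc3s2)c(Cl)c1` differs from compound 2 by methoxy in place of hydrogen on an aromatic carbon. Within the data shown here, no measured step bears on this change, and compound 2 itself stands at the limit, so neither size nor direction can be taken from the measured values. Compound 4 is therefore expected to remain near the limit, estimated at 100000 nM with a range of 30000 nM to 300000 nM. The expected step is then a number no higher from compound 2 to compound 4 (the limit leaves the size open), nothing beyond the scatter.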

Compound 4, half-maximal inhibitory concentration: > 100000 nM
Compound 4: only a limit was reported; the forecaster's own chance of this, stated with the estimate: 75%; the middle value lies on the limit itself.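

No step can be read between compound 2 and compound 4, since both stand at a limit: the limit of > 100000 nM in this assay, at which 4 of the 4 values shown sit. The compounds shown leave open whether methoxy in place of hydrogen has any effect in this assay, in size or direction.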